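Chain Lengthening and Ring Swap at a Cytotoxicity Limit

The source may hold more compounds than are shown below. What is called first, only, known or untested is meant among the compounds shown, and "the series" means these compounds.

Compound 1 `C/C=C/C(=O)Nc1cccc(Oc2nc(Nc3cccc(C#N)c3)nc3c2CSCC3)c1`, compound 2 `CC/C=C/C(=O)Nc1cccc(Oc2nc(Nc3cccc(C#N)c3)nc3c2CSCC3)c1` and compound 3 `C/C=C/C(=O)Nc1cccc(Oc2nc(Nc3ccc(OC)nc3)nc3c2CSCC3)c1` share one core and were all run in an ADME assay on L02 cells (Homo sapiens) for cytotoxicity, read by MTT assay, with a stated time of 72 h; on this read-out lower numbers stand for stronger inhibition and higher numbers for weaker inhibition. In this assay compound 1 gives > 50000 nM, which is a limit of the assay and not a number. Compound 2 likewise gives > 50000 nM in this assay, again a limit. Compound 3 also gives > 50000 nM in this assay, once more a limit. The change from compound 1 to compound 2 is methyl in place of hydrogen on a saturated chain carbon bound to a double-bonded chain carbon, and its step is a step that the two limits leave unreadable from compound 1 to compound 2. The change from compound 1 to compound 3 is 6-methoxypyridin-3-yl in place of 3-cyanophenyl on a nitrogen on an aromatic ring, with a step that the two limits leave unreadable from compound 1 to compound 3. That every value sits at one and the same limit is recorded in the limit of > 50000 nM in this assay, at which 3 of the 3 values shown sit.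

Compound 4 `CC/C=C/C(=O)Nc1cccc(Oc2nc(Nc3ccc(OC)nc3)nc3c2CSCC3)c1` has not yet been measured. It differs from compound 3 by methyl in place of hydrogen on a saturated chain carbon bound to a double-bonded chain carbon, the same change as that made from compound 1 to compound 2. The step from compound 3 to compound 4 is expected to be a step that the limit leaves unreadable from compound 3 to compound 4, placed beside a step that the two limits leave unreadable from compound 1 to compound 2, because compound 3 gives > 50000 nM and the earlier step that the two limits leave unreadable from compound 1 to compound 2 left the value at the limit. Compound 4 is therefore estimated at 60000 nM, between 30000 nM and 150000 nM.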

Compound 4, half-maximal inhibitory concentration: > 50000 nM
Compound 4 ended at the assay's limit (the forecaster's own chance of this, stated with the estimate: 85%); the middle value lies beyond the limit too.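

No step to compound 4, whether from compound 3 or from compound 2, can be read in this assay, because all four compounds stand at the same limit of the assay and not at a number: the limit of > 50000 nM in this assay, at which 4 of the 4 values shown sit.

The compounds shown leave open how far any of them lies from that limit, and so whether either change has any size here.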